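Methyl on the hydroxy oxygen of compound 2

The compounds below may be only part of what the source reports. "The series", "measured", "known", "first", "only" and "open" are said of these compounds alone.

Three compounds have been run in a functional assay on NCI-H460 cells (Homo sapiens) for inhibition, read by sulforhodamine B assay, with a stated time of 48 h, tested at 10 uM; a higher number here means a weaker effect of the compound at the concentration tested, a lower number a stronger effect: compound 1 `O=C(Nc1cccc(-n2cc(-c3ccncc3)c(-c3cc(O)cc(Cl)c3)n2)c1)Nc1ccc(Cl)c(C(F)(F)F)c1`, compound 2 `O=C(Nc1cccc(-n2cc(-c3ccncc3)c(-c3cc(O)cc(Cl)c3)n2)c1)Nc1ccc(Cl)c(Cl)c1` and compound 3 `COc1cc(Cl)cc(-c2nn(-c3cccc(NC(=O)Nc4cc(C(F)(F)F)cc(C(F)(F)F)c4)c3)cc2-c2ccncc2)c1`. In this assay compound 1 gives 3.75%, compound 2 gives 0.21% and compound 3 gives 0.24%. Compound 2 reads the lowest of the three numbers, but compound 3 and compound 1 both lie within the scatter of it, so no ranking can be drawn. Going by the values given here, the only single-point step measured so far, a number 3.5 percentage points lower from compound 1 to compound 2 (within the scatter), is itself within the scatter.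

Compound 4 `COc1cc(Cl)cc(-c2nn(-c3cccc(NC(=O)Nc4ccc(Cl)c(Cl)c4)c3)cc2-c2ccncc2)c1` has not yet been measured in this assay. It differs from compound 2 by methyl in place of hydrogen on an oxygen on an aromatic ring. Among the compounds with values here, no measured step covers this change: the step from compound 1 to compound 2 concerns chloro in place of trifluoromethyl on an aromatic carbon and was within the scatter. Compound 3 carries the methoxy group that compound 4 gains, and its value beside that of compound 2 shows no gap beyond the scatter, though the two differ in more than one place. Nothing here supports a step beyond the scatter in either direction, so the expected step of a number 0.8 percentage points higher from compound 2 to compound 4 (within the scatter) is small. Compound 4 is estimated at 1%, with a range from 0% to 10%.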

Compound 4, a percentage reported as activity, at one concentration (the size of the read-out at that concentration, not a potency): 3.1%
Compound 4: the middle estimate sits 2.1 percentage points below what was measured, within the range that was stated.
By their numbers in this assay, from the lowest: compounds 2, 3, 4 and 1 (each within the scatter of the next).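

Going by these compounds alone, replacing the hydrogen on the oxygen with methyl, hydroxy to methoxy on the 3-chloro-5-hydroxyphenyl group, gives in this assay a number 2.9 percentage points higher from compound 2 to compound 4 (within the scatter) and is the first single change read at this oxygen. The free hydroxy is therefore not required to keep the read-out of this series at the tested concentration, and methoxy is tolerated here on the dichlorophenyl urea side as far as this one read-out can tell. Nothing available bears on why the change leaves the read-out within the scatter.

The read-out comes from one concentration. It gives the size of the effect at that concentration and not a potency, and a difference between hydroxy and methoxy could still exist at lower concentrations. Also open, going by these compounds, is how far this oxygen tolerates change: an ethyl or a longer chain on the oxygen, a chain ending in an amine or a carboxylic acid, or an amine in place of the hydroxy could each test whether the read-out holds beyond methyl.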